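A Heteroaryl Ether in Place of an Alkylamine

A few compounds are considered here, and "the series" means these few. Any claim that something is new, unique, unknown or untested is made for them only; others in the source may bear on it.

Compound 1, `CCCCNc1nc(N)nc2ccn(Cc3ccccc3)c12`: in an ADME assay on HEK293 cells (Homo sapiens) for cytotoxicity, read by ATP content, with a stated time of 6 h (on this read-out lower numbers stand for higher toxicity in this test and higher numbers for lower toxicity in this test), compound 1 gives only the limit > 24000 nM.
Compound 2, `COCCNc1nc(N)nc2ccn(Cc3ccccn3)c12`: in this assay compound 2 gives only the limit > 24000 nM.

Compound 2 thus stands together with compound 1 at the limit of > 24000 nM in this assay, at which 2 of the 2 values shown sit, so neither compound has an actual number, and no order between the two can be drawn. Compound 3, `Cc1cnc(COc2nc(N)nc3ccn(Cc4ccccn4)c23)o1`, has not yet been measured. It differs from compound 2 by (5-methyl-1,3-oxazol-2-yl)methoxy in place of (2-methoxyethyl)amino on an aromatic carbon. Among the measured compounds shown here, no measured step exists between any two compounds here, so the expectation for compound 3 in this assay is a change of none beyond the scatter, with the most likely outcome that compound 3 again reaches only the limit. The estimate for compound 3 in this assay is 30000 nM, expected within 10000 nM to 100000 nM. That estimate corresponds to an expected step that the limit leaves unreadable from compound 2 to compound 3.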

Compound 3, half-maximal cytotoxic concentration: > 24000 nM
Compound 3 gave a limit, no number; the forecaster's own chance of this, stated with the estimate: 75%; the middle value does not contradict the limit.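

Among the compounds shown here, compound 3, like compound 2, gives only a limit in this assay, so no step between these two compounds can be read: the limit of > 24000 nM in this assay, at which 3 of the 3 values shown sit. The compounds shown leave open how far apart their true half-maximal cytotoxic concentrations lie, and whether the change of group matters in this test.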